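Stripping the Isobutyl from a Fused Lactam Core

The source may report more compounds than this note shows. Statements on the series, on what has been measured and on what is new or still open speak of the compounds shown alone.

Among the measured compounds shown here, compound 2 `CC(C)CC1(CCCCN2CCN(c3cccc(Cl)c3)CC2)C(=O)Nc2ccccc21` is the only member of this small set with a real number in a functional assay on the whole organism (strain Wistar) with Rattus norvegicus as the target, with a stated time of 5 min (a higher number here means that more compound is needed for the effect, a lower number that less compound is needed), where compound 2 gives 10 mg/kg. Compound 1 `CCC1(CCCCN2CCN(c3cccc(Cl)c3)CC2)C(=O)Nc2c(Cl)cc(Cl)cc21` reaches only a limit of the test, giving > 20 mg/kg in this assay. Compound 3 `CCC1(CCCCN2CCN(c3ccc(C)c(Cl)c3)CC2)C(=O)Nc2ccccc21` likewise stops at a limit in this assay, where compound 3 gives > 20 mg/kg. Two of the three results thus rest at the limit of > 20 mg/kg in this assay, at which 2 of the 3 values shown sit. Compound 4 `O=C1Nc2ccccc2C1CCCCN1CCN(c2cccc(Cl)c2)CC1` has not yet been tested; it differs from compound 2 by hydrogen in place of isobutyl on a saturated ring carbon. For the measured compounds named here, with no measured step to lean on, the expectation is a modest shift toward more compound being needed, a step of a 2.0-fold higher number from compound 2 to compound 4 (0.30 log units; within the scatter). Compound 4 is therefore estimated at 20 mg/kg, most likely falling between 6 mg/kg and 40 mg/kg.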

Compound 4, minimum effective dose: < 5 mg/kg
Compound 4: a limit, no number; the forecaster's own chance of this, stated with the estimate: 45%; middle value at least 4.0-fold (0.60 log units) away from the limit.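

Replacing isobutyl with hydrogen on this saturated ring carbon gives an at least 2.0-fold lower number from compound 2 to compound 4 (0.30 log units; that floor lies within the scatter) in this assay, so the effect in this assay does not depend on keeping the isobutyl. Compound 4 gives < 5 mg/kg, which is a limit of the test and not a number. The full size of the step cannot be read because the result rests at a limit: the limit of < 5 mg/kg in this assay, at which 1 of the 4 values shown sits.

The compounds shown leave open how a methyl or a hydroxyl on this ring carbon would compare with hydrogen and isobutyl. They also leave open how far the number could fall with hydrogen here.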